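Removing the Sulfamoyl Group from Compound 1

The compounds below may be only part of what the source reports. "The series", "measured", "known", "first", "only" and "open" are said of these compounds alone.

Measured so far:
Compound 1 `N#CC1CN1C(=O)Nc1ccc(S(N)(=O)=O)cc1` — > 38000 nM
Compound 2 `N#CC1CN1C(=O)NC1CCCCC1` — 98000 nM

The study looks at inhibition in a functional assay on RPMI-8226 cells (Homo sapiens) for inhibition; a lower number here means a stronger inhibitor, a higher number a weaker inhibitor. Compound 1 is known in this assay only as a limit, > 38000 nM, and not as a number. Compound 1 stands at the limit of > 38000 nM in this assay, at which 1 of the 2 values shown sits. Compound 2, in turn, gives 98000 nM in this assay. Among the measured compounds shown here, the two compounds differ in more than one place, so no single step between them can be read; all their values show is that both are weak inhibitors, one with a number, the other without one.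

The next compound is compound 3 `N#CC1CN1C(=O)Nc1ccccc1`, not yet measured. It differs from compound 1 by hydrogen in place of sulfamoyl on an aromatic carbon. For the measured compounds named here, no measured step speaks to such a change, and the two known values give no sign of a direction. The author therefore expects in this assay no step beyond the usual scatter, in either direction. For compound 3 he estimates 60000 nM, with a range from 12000 nM to 300000 nM. That estimate amounts to an expected step that the limit leaves unreadable from compound 1 to compound 3, and the measurement will decide.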

Compound 3, half-maximal inhibitory concentration: 8000 nM
Compound 3: the middle estimate sits 7.5-fold (0.88 log units) above what was measured; the whole stated range lies above it.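

In this assay, the group on this aromatic carbon, para to a group of 8 heavy atoms, proves not to be indifferent: hydrogen in place of sulfamoyl gives an at least 4.7-fold lower number from compound 1 to compound 3 (0.67 log units; beyond the scatter). This is the only step that can be read among the compounds shown, and it points in one direction, with the compound that lacks the sulfamoyl group, compound 3, as the stronger inhibitor of the pair, though still a weak one on the scale of this series alone cannot be judged further. From the compounds shown here alone, the full size of the step stays unknown, since compound 1 is held only as a limit: the limit of > 38000 nM in this assay, at which 1 of the 3 values shown sits.

One replacement at one place cannot tell whether the gain comes from losing the sulfamoyl group as such or whether other groups on this carbon would do as well. Going by these compounds, whether an amine, a carboxylic acid, a methyl group or a halogen such as chlorine at this same place would keep, enlarge or undo the step remains open, as does whether a substituent at any other carbon of the ring would behave alike.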